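Chalcone triazole series: methoxy to nitro on the aroyl ring

The source may report more compounds than this note shows. Statements on the series, on what has been measured and on what is new or still open speak of the compounds shown alone.

Measured compounds:
- compound 1 `COc1ccc(C(=O)/C=C/c2ccc(OCc3cn(Cc4ccc(Br)cc4)nn3)cc2)cc1`: 56%
- compound 2 `COc1ccc(C(=O)/C=C/c2ccc(OCc3cn(Cc4ccccc4F)nn3)cc2)cc1`: 19%
- compound 3 `COc1ccc(C(=O)/C=C/c2ccc(OCc3cn(Cc4cccc(F)c4)nn3)cc2)cc1`: 48%

All three numbers come from a functional assay on MIA PaCa-2 cells (Homo sapiens) for inhibition, read by MTT assay, with a stated time of 48 h, tested at 10 uM; on this read-out lower numbers stand for less inhibition of growth and higher numbers for more inhibition of growth at the one concentration tested. Compound 3 gives 48%, the second highest of the three; its nearest neighbour is compound 1, and the two lie within the scatter of each other, as the step of a number 8 percentage points lower from compound 1 to compound 3 (within the scatter) shows. The other steps, a number 37 percentage points lower from compound 1 to compound 2 (beyond the scatter) and a number 29 percentage points higher from compound 2 to compound 3 (beyond the scatter), are both beyond the scatter, and all three measured steps concern only the substituted phenyl on the saturated chain carbon bound to the aromatic nitrogen.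

Compound 4 `O=C(/C=C/c1ccc(OCc2cn(Cc3cccc(F)c3)nn2)cc1)c1ccc([N+](=O)[O-])cc1` differs from compound 3 elsewhere: nitro in place of methoxy on an aromatic carbon. For the measured compounds named here, no measured step touches this position, so the measured steps bear on it only indirectly; they show that single-group exchanges can move this assay by modest to large amounts, but give no direction for this exchange. The expectation is therefore a step of uncertain direction, wide in range, centred close to the value of compound 3: a number 3 percentage points lower from compound 3 to compound 4 (within the scatter). Compound 4 is estimated at 45%, with a range from 15% to 75%.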

Compound 4, percent growth inhibition at one concentration: 32%
Estimate against measurement, compound 4: 13 percentage points above; measured number inside the range.
By their numbers in this assay, from the lowest: compound 2; then compound 4; then compounds 3 and 1 (each within the scatter of the next).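

In this assay, for the compounds shown here, the exchange of 4-methoxyphenyl for 4-nitrophenyl on the carbonyl gives a number 16 percentage points lower from compound 3 to compound 4 (beyond the scatter) and so shows that this position, which the earlier steps left untouched, also affects the read-out. With the 3-fluorophenyl group held constant, nitro in place of methoxy now has a measured direction: less growth inhibition at the one concentration tested. No measurement among these compounds accounts for this step.

This single pair leaves open whether the step would keep its direction and size with the 4-bromophenyl or 2-fluorophenyl group at the other end of the molecule. On these data alone, how an amine, a carboxylic acid or a plain hydrogen at this place on the ring would read also remains open.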